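Shortening the hydroxycarbamoyl chain on the shared core

The compounds below may be only part of what the source reports. "The series", "measured", "known", "first", "only" and "open" are said of these compounds alone.

In a functional assay on SNU-423 cells (Homo sapiens) for inhibition, read by MTT assay, with a stated time of 72 h (a higher number here means a weaker inhibitor, a lower number a stronger inhibitor), compound 3 `Nc1ncnc2c1c(-c1cnc3[nH]ccc3c1)nn2CCCCCCCCCC(=O)NO` gives 8160 nM and stands level with the other two measured compounds. Compound 2 `Nc1ncnc2c1c(-c1cnc3[nH]ccc3c1)nn2CCCCCCCCC(=O)NO` gives 7500 nM in the same test and compound 1 `CNC(=O)CCCCCCCn1nc(-c2cnc3[nH]ccc3c2)c2c(N)ncnc21` gives 5400 nM there, and all three values lie within the scatter of one another.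

Compound 4 `Nc1ncnc2c1c(-c1cnc3[nH]ccc3c1)nn2CCCCCCC(=O)NO` differs from compound 3 by hydroxycarbamoyl in place of 3-(hydroxycarbamoyl)propyl on a saturated chain carbon, six bonds along the chain from an aromatic nitrogen in one change: hydroxycarbamoyl in place of 3-(hydroxycarbamoyl)propyl on a saturated chain carbon, six bonds along the chain from an aromatic nitrogen. The nearest measured chain change is a 1.1-fold higher number from compound 2 to compound 3 (0.04 log units; within the scatter) and lies within the scatter. The two steps that also replace the end group, a 1.4-fold higher number from compound 1 to compound 2 (0.14 log units; within the scatter) and a 1.5-fold higher number from compound 1 to compound 3 (0.18 log units; within the scatter) as well, stay within it. No chain as short as that of compound 4 has been measured, so this is an extrapolation. No step beyond the scatter is expected, and the estimated move is a 1.2-fold lower number from compound 3 to compound 4 (0.07 log units; within the scatter) on this evidence. Compound 4 is estimated at 7000 nM with an expected range of 3500 nM to 14000 nM for this measurement.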

Compound 4, half-maximal inhibitory concentration: 7500 nM
Compound 4: middle estimate off by 1.1-fold (0.03 log units), on the low side, and the stated range covers the measured number.
By their numbers in this assay, from the lowest: compounds 1, 2, 4 and 3 (each within the scatter of the next).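

Working notes: in this assay, the hydroxycarbamoyl chain can be shortened at this position, six bonds along the chain from an aromatic nitrogen, without the number leaving the scatter (a 1.1-fold lower number from compound 3 to compound 4 (0.04 log units; within the scatter); no change at the digits printed from compound 2 to compound 4 (within the scatter)), so the flat reading now extends across compounds 2, 3 and 4. The combined change of chain and end group from the methylcarbamoyl series member also stays within the scatter (a 1.4-fold higher number from compound 1 to compound 4 (0.14 log units; within the scatter)), so neither change separates these compounds in this test. Nothing available explains this flat reading.

Still open, as far as these compounds go, is whether a shorter chain than hydroxycarbamoyl on this carbon gives a step beyond the scatter. A carboxylic acid or a primary amine at the chain end would show whether any end group at this position moves the number.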